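The source may report more compounds than this note shows. Statements on the series, on what has been measured and on what is new or still open speak of the compounds shown alone.

Measured so far:
compound 1 `O=C1C(Nc2ccc(Oc3ccccc3)cc2)=CC(=O)c2ncncc21` — 1800 nM
compound 2 `O=C1C(Nc2ccc(-c3ccc(F)cc3)cc2)=CC(=O)c2ncncc21` — 3200 nM
compound 3 `COc1ccc(NC2=CC(=O)c3ncncc3C2=O)cc1` — 800 nM

These three compounds share one core and differ only in the group carried on an aromatic carbon of the outer ring. In a functional assay on PANC-1 cells (Homo sapiens) for cytotoxicity, read by MTT assay, with a stated time of 72 h (a higher number here means a weaker inhibitor, a lower number a stronger inhibitor), compound 3 gives the lowest of the three numbers: the step of a 2.3-fold lower number from compound 1 to compound 3 (0.35 log units; beyond the scatter) and the step of a 4.0-fold lower number from compound 2 to compound 3 (0.60 log units; beyond the scatter) both lie beyond the scatter, so on these numbers compound 3 is the strongest inhibitor of the set. The two larger groups, phenoxy and 4-fluorophenyl, sit close together, as the step of a 1.8-fold higher number from compound 1 to compound 2 (0.25 log units; within the scatter) stays within the scatter.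

Compound 4 `O=C1C(Nc2ccc(-c3ccccc3)cc2)=CC(=O)c2ncncc21` carries the change (phenyl in place of methoxy on an aromatic carbon), placed on an aromatic carbon of a six-membered aromatic ring of carbon only, para to a large group. The step that bears most directly on it is a 4.0-fold lower number from compound 2 to compound 3 (0.60 log units; beyond the scatter), since compound 4 differs from compound 2 only by the absence of fluorine; the step of a 2.3-fold lower number from compound 1 to compound 3 (0.35 log units; beyond the scatter) points the same way. The reverse of those steps, a modest rise in number, is therefore expected for compound 4, with an estimated step of a 3.1-fold higher number from compound 3 to compound 4 (0.49 log units; beyond the scatter).

Compound 4 is accordingly estimated at 2500 nM in this assay, within a range of 1000 nM to 6000 nM.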

Compound 4, half-maximal inhibitory concentration: 400 nM
Beside the measured number, compound 4's estimate is 6.3-fold (0.80 log units) above it; measured number below the stated range.
By their numbers in this assay, from the lowest: compounds 4 and 3 (each within the scatter of the next); then compounds 1 and 2 (each within the scatter of the next).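

In this assay the size of the group on this aromatic carbon does not by itself set the number: phenyl brings a whole ring and more heavy atoms in place of methoxy, yet a 2.0-fold lower number from compound 3 to compound 4 (0.30 log units; within the scatter) stays within the scatter, so these small and large groups cannot be told apart here. The large groups, which had looked alike, now separate on small details, since hydrogen in place of fluoro gives an 8.0-fold lower number from compound 2 to compound 4 (0.90 log units; beyond the scatter) and phenyl in place of phenoxy gives a 4.5-fold lower number from compound 1 to compound 4 (0.65 log units; beyond the scatter) with both steps beyond the scatter. No measurement at hand accounts for these differences.

In this assay the compounds shown leave open how an amine, a carboxylic acid or a longer alkyl chain on this aromatic carbon would read. They also leave open whether the sensitivity to fluoro on the outer phenyl ring extends to other groups there, such as chloro or methoxy, or belongs to fluoro alone.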